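This account rests on a few compounds, and the source may have more. Where it says the series, first, only, none or still open, it means among the compounds named here.

Compound 2 `O=[N+]([O-])c1ccc(-c2nc3cccnc3o2)cc1` gives 5% in a functional assay on the whole organism for inhibition, with Rattus norvegicus as the target, at a dose of 30 mg/kg; on this read-out higher numbers stand for more inhibition at the one dose given (going by the name of the read-out) and lower numbers for less inhibition. Within the data shown here, it stands beside a single other measured compound, compound 1 `Cc1ccc(-c2nc3cccnc3o2)cc1`, which gives 0%, and the one known step, a number 5 percentage points higher from compound 1 to compound 2 (within the scatter), lies within the scatter. Compound 3 `Clc1ccc(-c2nc3cccnc3o2)cc1` is still unmeasured and differs from compound 2 in one place: chloro in place of nitro on an aromatic carbon. Among the measured compounds shown here, no measured step swaps a nitro for a chloro, so the expectation rests only on the small step seen so far. For compound 3 the expected step is a number 2 percentage points lower from compound 2 to compound 3 (within the scatter), nothing beyond the scatter. Compound 3 is therefore estimated at 3%, between -6% and 12%.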

Compound 3, a percentage reported as inhibition, in the whole organism at one dose (the size of the read-out at that dose, not a potency): 14%
Compound 3: middle estimate off by 11 percentage points, on the low side; measured number outside the range, above it.
By their numbers in this assay, from the lowest: compounds 1, 2 and 3 (each within the scatter of the next, the first and the last beyond it).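

Among these compounds, at this position, on the aromatic carbon para to a group of 9 heavy atoms, this assay now shows that the choice of group can matter: chloro in place of methyl gives a number 14 percentage points higher from compound 1 to compound 3 (beyond the scatter) and is the first step to clear the usual noise. Chloro in place of nitro gives a number 9 percentage points higher from compound 2 to compound 3 (within the scatter) and so does not separate those two groups. Nothing available here accounts for the gain with chloro. Still open, going by these compounds, is how an amine or a carboxylic acid at this position would compare. Also open, on these data alone, is whether chloro keeps its edge over methyl on a different core.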